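Replacing benzoylcarbamoyl on an amine nitrogen of compound 3

A few compounds are considered here, and "the series" means these few. Any claim that something is new, unique, unknown or untested is made for them only; others in the source may bear on it.

Going by the values given here, in a functional assay on MT4 cells (Homo sapiens) (a lower number here means that less compound is tolerated, a higher number that more compound is tolerated), compound 3 (`Cc1cn([C@@H]2O[C@H](CO[Si](C)(C)C(C)(C)C)[C@@]3(OS(=O)(=O)C=C3NC(=O)NC(=O)c3ccccc3)[C@H]2O[Si](C)(C)C(C)(C)C)c(=O)n(C)c1=O`) gives 3330 nM and holds the lowest of the three numbers so far. Compound 1 (`Cc1cn([C@@H]2O[C@H](CO[Si](C)(C)C(C)(C)C)[C@@]3(OS(=O)(=O)C=C3NCC(=O)O)[C@H]2O[Si](C)(C)C(C)(C)C)c(=O)n(C)c1=O`) gives 30000 nM and compound 2 (`COC(=O)NC1=CS(=O)(=O)O[C@@]12[C@@H](CO[Si](C)(C)C(C)(C)C)O[C@@H](n1cc(C)c(=O)n(C)c1=O)[C@@H]2O[Si](C)(C)C(C)(C)C`) gives 29900 nM on the same scale, with the same core and a different group on the amine nitrogen.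

Compound 4 (`Cc1cn([C@@H]2O[C@H](CO[Si](C)(C)C(C)(C)C)[C@@]3(OS(=O)(=O)C=C3NCC(=O)C(N)=O)[C@H]2O[Si](C)(C)C(C)(C)C)c(=O)n(C)c1=O`) carries (carbamoylcarbonyl)methyl in place of benzoylcarbamoyl on an amine nitrogen. Among the compounds with values here, three measured steps bear on this. One is flat and within the scatter: a 1.0-fold lower number from compound 1 to compound 2 (0.00 log units; within the scatter) for methoxycarbonyl in place of carboxymethyl. The two that install benzoylcarbamoyl are modest and beyond the scatter: a 9.0-fold lower number from compound 1 to compound 3 (0.95 log units; beyond the scatter) and a 9.0-fold lower number from compound 2 to compound 3 (0.95 log units; beyond the scatter) are the only shifts seen.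

Compound 4 gives up that group, and its new chain has no ring, so it should move back towards compound 1 (30000 nM) without quite certainly reaching it. The expected change is a 6.6-fold higher number from compound 3 to compound 4 (0.82 log units; beyond the scatter) in this assay and so a clear move upwards. For compound 4 the estimate is 22000 nM (expected range 7000 nM to 60000 nM).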

Compound 4, half-maximal cytotoxic concentration: 9590 nM
Beside the measured number, compound 4's estimate is 2.3-fold (0.36 log units) above it; low and high end bracket the measured number.
By their numbers in this assay, from the lowest: compound 3; then compound 4; then compounds 2 and 1 (each within the scatter of the next).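

In this assay, a lower number at this amine nitrogen does not depend on an aromatic ring: the ring-free (carbamoylcarbonyl)methyl group also gives one, both against methoxycarbonyl (a 3.1-fold lower number from compound 2 to compound 4 (0.49 log units; beyond the scatter)) and when carbamoyl replaces hydroxy on a carbonyl carbon (a 3.1-fold lower number from compound 1 to compound 4 (0.50 log units; beyond the scatter)). Removing benzoylcarbamoyl still raises the number (a 2.9-fold higher number from compound 3 to compound 4 (0.46 log units; beyond the scatter)), so the position now shows three levels rather than two, with the ring-free chain in the middle. No measurement in hand explains this order.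

On these data alone, it remains open whether a plain benzoyl group on this nitrogen would give a number as low as the benzoylcarbamoyl group does. As far as these compounds go, it is also open whether a longer chain ending in an amine would follow the ring-free chain here.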